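Phenoxy in Place of Methoxyphenyl on the Side Chain

The source may hold more compounds than are shown below. What is called first, only, known or untested is meant among the compounds shown, and "the series" means these compounds.

Among the compounds with values here, compound 2 `COc1ccc(CC2CCCCN2C(=O)n2ncc(C(O)(c3ccc(F)cc3)c3ccc(F)cc3)n2)cc1` stands as the higher of the two numbers so far obtained in an assay on isolated protein for inhibition of Monoacylglycerol lipase ABHD6 (Homo sapiens), read by fluorescence; on this read-out lower numbers stand for stronger inhibition and higher numbers for weaker inhibition: compound 2 gives 251 nM, whereas compound 1 `O=C(N1C[C@H](O)C=C[C@@H]1Cc1ccccc1)n1ncc(C(O)(c2ccc(F)cc2)c2ccc(F)cc2)n1` gives 39.8 nM in this assay, a gap that lies beyond the usual scatter. Compound 3 `O=C(N1CCCCC1COc1ccccc1)n1ncc(C(O)(c2ccc(F)cc2)c2ccc(F)cc2)n1` has not yet been measured. It differs from compound 2 in one place: phenoxy in place of 4-methoxyphenyl on a saturated chain carbon bound to a saturated ring carbon. Within the data shown here, no pair of measured compounds differs in just this way, so the step has no measured precedent. Among the measured compounds shown here, compound 2 and compound 1 differ in several places at once, and their values show only that compound 1 reaches 39.8 nM. For compound 3 the estimated step is a 1.3-fold lower number from compound 2 to compound 3 (0.10 log units; within the scatter), not clearly beyond the scatter in either direction. The expected value for compound 3 in this assay is 200 nM, within a range from 60 nM to 700 nM.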

Compound 3, half-maximal inhibitory concentration: 200 nM
Compound 3: the middle estimate sits on the measured number at the digits printed; low and high end bracket the measured number.
By their numbers in this assay, from the lowest: compound 1; then compounds 3 and 2 (each within the scatter of the next).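

In this assay, within the data shown here, phenoxy in place of 4-methoxyphenyl on a saturated chain carbon bound to a saturated ring carbon gives a 1.3-fold lower number from compound 2 to compound 3 (0.10 log units; within the scatter), the first comparison at this position that changes one place only. The side chain can thus go from 4-methoxybenzyl to phenoxymethyl with no change in the number that stands beyond the scatter. Nothing available bears on why these two side chains do not separate.

Compound 1 differs from both compounds in several places, so its lower number cannot be traced to the side chain alone. Also open, as far as these compounds go, is whether a different group on this chain, such as an amine, a carboxylic acid or a longer chain ending in phenoxy, would move the number beyond the scatter.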